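The source may hold more compounds than are shown below. What is called first, only, known or untested is meant among the compounds shown, and "the series" means these compounds.

Measured so far:
compound 1, `COC(=O)N1N=C(c2ccccc2)CC1c1cc(OC)c(OC)c(OC)c1`: 6260 nM
compound 2, `COC(=O)N1N=C(c2cccc(Cl)c2)CC1c1cc(OC)c(OC)c(OC)c1`: 140 nM

Both values come from a functional assay on HT-29 cells (Homo sapiens) for antiproliferative activity, read by MTT assay, with a stated time of 48 h; on this read-out higher numbers stand for weaker inhibition of growth and lower numbers for stronger inhibition of growth. For the measured compounds named here, compound 2 stands lowest of the two numbers, and the only step between them, a 45-fold lower number from compound 1 to compound 2 (1.65 log units; beyond the scatter), shows how much one change on the aromatic ring attached to the carbon with a double bond to nitrogen can move the read-out. Compound 3, `COC(=O)N1N=C(c2ccc(OC)c(OC)c2)CC1c1cc(OC)c(OC)c(OC)c1`, alters that same ring again: 3,4-dimethoxyphenyl in place of 3-chlorophenyl on a carbon with a double bond to nitrogen. Going by the values given here, the one measured step bears on this change only loosely, since it tells what the chloro contributes relative to hydrogen, not what two methoxy groups do in its place. Taking the chloro away is expected to cost potency, while the entering groups may give some of it back, so a rise in this assay beyond the scatter is expected, but smaller than the measured step. Compound 3 is therefore estimated at 1200 nM in this assay, with a range of 150 nM to 8000 nM, which is the step of an 8.6-fold higher number from compound 2 to compound 3 (0.93 log units; beyond the scatter) expected from compound 2.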

Compound 3, concentration for 50% growth inhibition: 9200 nM
The estimate for compound 3 lay 7.7-fold (0.88 log units) below the measured number; measured number outside the range, above it.
By their numbers in this assay, from the lowest: compound 2; then compounds 1 and 3 (each within the scatter of the next).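

In this assay, the change to 3,4-dimethoxyphenyl brings a 66-fold higher number from compound 2 to compound 3 (1.82 log units; beyond the scatter) and so removes the low number that the 3-chlorophenyl group gave. Compared with the plain phenyl, the same group gives a 1.5-fold higher number from compound 1 to compound 3 (0.17 log units; within the scatter) and therefore lies within the scatter, which shows that placing substituents on this ring does not by itself lower the number. Among these three compounds, only compound 2 at 140 nM stands apart, so the identity of the groups on this ring matters, not simply whether the ring carries any; nothing given here explains this difference.

The compounds shown leave open whether the low number belongs to the chloro group alone or would also appear with a bromo, methyl or single methoxy group on the ring in its place. They also leave open how an amine or a carboxylic acid on this ring would compare, and whether either methoxy group of 3,4-dimethoxyphenyl would behave differently on its own.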